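This account rests on a few compounds, and the source may have more. Where it says the series, first, only, none or still open, it means among the compounds named here.

Measured in an assay on HeLa cells for inhibition of sphingosine-1-phosphate transporter SPNS2 (Mus musculus), read by LC-MS, tested at 2 uM; a lower number here means less inhibition, a higher number more inhibition at the concentration tested (going by the name of the read-out):
Compound 1 `CCCCCCCCCCc1ccc(-c2noc(C3CCNC3)n2)cc1` gives 26%.
Compound 2 `CCCCCCCCCCc1ccc(-c2noc([C@H]3CCCN3)n2)cc1` gives 12%.
Compound 3 `CCCCCCCCCCc1ccc(-c2noc([C@@H]3CCC[C@@H](N)C3)n2)cc1` gives 13%.

Compound 2 stands at the low end of these three numbers: a number 14 percentage points lower from compound 1 to compound 2 (beyond the scatter), while compound 3 sits within the scatter of it, a number 1 percentage points higher from compound 2 to compound 3 (within the scatter). Compound 4 `CCCCCCCCCCc1ccc(-c2noc([C@@H](N)CCN)n2)cc1` differs from compound 2 in one place: 1,3-diaminopropyl in place of pyrrolidin-2-yl on an aromatic carbon. Going by the values given here, no measured step exchanges pyrrolidin-2-yl for a group with no ring, so the guide is indirect. The steps that exist, a number 14 percentage points lower from compound 1 to compound 2 (beyond the scatter) and a number 13 percentage points lower from compound 1 to compound 3 (beyond the scatter), show that exchanging one amine-bearing group for another shifts this assay only modestly, and all three compounds stay low. A modest step at most is therefore expected here, a number 8 percentage points higher from compound 2 to compound 4 (within the scatter), with no firm direction. The estimate for compound 4 in this assay is 20%, within 5% to 40%.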

Compound 4, a percentage reported as inhibition, at one concentration (the size of the read-out at that concentration, not a potency): 14%
Estimate against measurement, compound 4: 6 percentage points above, within the range that was stated.
By their numbers in this assay, from the lowest: compounds 2, 3 and 4 (each within the scatter of the next); then compound 1.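

Going by these compounds alone, compound 4 puts the first group with no ring at this place on the core, and in this assay giving up the ring makes no readable difference: a number 2 percentage points higher from compound 2 to compound 4 (within the scatter), and a number 1 percentage points higher from compound 3 to compound 4 (within the scatter). Compound 1, with pyrrolidin-3-yl, remains apart, with a number 12 percentage points lower from compound 1 to compound 4 (beyond the scatter). Nothing measured here gives a cause for these numbers.

Still open, as far as these compounds go, is whether a piperidine ring, or an open chain carrying a single amine, would read closer to compound 1 or stay with the other three.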